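The compounds below may be only part of what the source reports. "The series", "measured", "known", "first", "only" and "open" are said of these compounds alone.

Working notes on the series. In a functional assay on PC-12 cells (Rattus norvegicus) for inhibition, read by sulforhodamine B assay (a higher number here means a weaker inhibitor, a lower number a stronger inhibitor), compound 1 (`O=C1NC(=O)C(Cc2ccc(OCC3CCCCO3)cc2)S1`) gives > 100000 nM, which is a limit of the assay and not a number. Compound 1 therefore stands at the limit of > 100000 nM in this assay, at which 1 of the 2 values shown sits, and no exact size can be given to any step that starts from it. Among the compounds with values here, compound 2 (`O=C1N=C(O)S/C1=C\c1ccc(OCC2CCCCC2)cc1`) reads 14000 nM in this assay, the only true number so far.

Compound 3 (`O=C1NC(=O)C(Cc2ccc(OCC3CCCC3)cc2)S1`) keeps the core of compound 1 and carries cyclopentyl in place of oxan-2-yl on a saturated chain carbon bound to an oxygen on an aromatic ring. Within the data shown here, no measured pair isolates this change. A modest shift toward stronger inhibition is expected in this assay, and it may stay hidden if compound 3 also reads as a limit. The lean toward lower numbers rests on compound 2 at 14000 nM, which shows that a reading within the range of the assay occurs among these compounds.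

The expected step is an at least 1.6-fold lower number from compound 1 to compound 3 (0.22 log units; that floor lies within the scatter). For compound 3 the estimated value is 60000 nM, with an expected range of 20000 nM to 150000 nM.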

Compound 3, half-maximal inhibitory concentration: 25000 nM
The estimate for compound 3 lay 2.4-fold (0.38 log units) above the measured number, and the stated range covers the measured number.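

In this assay, cyclopentyl in place of oxan-2-yl on a saturated chain carbon bound to an oxygen on an aromatic ring gives an at least 4.0-fold lower number from compound 1 to compound 3 (0.60 log units; beyond the scatter), which shows that the reading responds to this position on the shared core and that an all-carbon ring here brings the value into the measurable range. For compound 1, > 100000 nM is a limit of the assay and not a number. The step therefore has only a floor, and its full size stays unknown because one end of it rests on that limit: the limit of > 100000 nM in this assay, at which 1 of the 3 values shown sits.

Within the data shown here, the change swaps a six-membered ring with one hetero atom for a five-membered ring of carbon only, and which of these two differences carries the step stays open; compound 2 differs from the other compounds in more than one place, and no step to it can be read. Also open, on these data alone, is how this assay would read with an amine or a carboxylic acid on this ring, or with a longer chain in place of cyclopentylmethyl.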